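The source may hold more compounds than are shown below. What is called first, only, known or untested is meant among the compounds shown, and "the series" means these compounds.

Measured compounds in an assay for positive allosteric modulation of metabotropic glutamate receptor 3 (Rattus norvegicus); on this read-out higher numbers stand for an effect only at larger amounts of compound and lower numbers for an effect already at smaller amounts:
compound 1 `Cc1ccc(OCCCCOc2ccc(C(=O)CC(C)(C)C)c(O)c2C)cc1C(=O)O` gives 309 nM
compound 2 `COc1ccc(C(=O)O)cc1OC[C@H](C)COc1ccc(C(=O)CC(C)(C)C)c(O)c1C` gives 384 nM
compound 3 `Cc1c(OC[C@@H](C)COc2cc(C(=O)O)ccc2F)ccc(C(=O)CC(C)(C)C)c1O` gives 3950 nM

Compound 3 stands at the highest of the three numbers. Compound 4 `Cc1cc(OC[C@H](C)COc2ccc(C(=O)CC(C)(C)C)c(O)c2C)ccc1C(=O)O` is not yet measured. Its structure differs from compound 3 in one place: 4-carboxy-3-methylphenyl in place of 5-carboxy-2-fluorophenyl on an oxygen on a saturated carbon. Within the data shown here, one measured step bears on this: a 10-fold higher number from compound 2 to compound 3 (1.01 log units; beyond the scatter), which undid itself in the other direction would bring the number back toward compound 2. The aryl group that enters is the same one carried by compound 1, which gives 309 nM in this assay. Compound 4 is therefore expected to give a clearly lower number than compound 3, estimated as a 9.9-fold lower number from compound 3 to compound 4 (0.99 log units; beyond the scatter), with a value of 400 nM and a range from 150 nM to 1100 nM.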

Compound 4, half-maximal effective concentration: 1350 nM
Compound 4: middle estimate off by 3.4-fold (0.53 log units), on the low side; the whole stated range lies below it.
By their numbers in this assay, from the lowest: compounds 1 and 2 (each within the scatter of the next); then compound 4; then compound 3.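

At the oxygen on a saturated carbon, a second aryl exchange also moves the number in this assay, with 4-carboxy-3-methylphenyl replacing 5-carboxy-2-fluorophenyl giving a 2.9-fold lower number from compound 3 to compound 4 (0.47 log units; beyond the scatter), so this position responds to more than the fluoro and methoxy exchange. Even so, compound 4 at 1350 nM does not reach the printed value of compound 2 at 384 nM. No measurement offered here explains the step.

The two aryl groups differ in more than one feature, so the share of the fluoro, the methyl and the carboxy placement stays unresolved. Going by these compounds, how a tetrazole in place of the carboxylic acid would read at this position also remains open.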